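Aryl Substituent Variation on the Shared Core: Bromo Analogue

A few compounds are considered here, and "the series" means these few. Any claim that something is new, unique, unknown or untested is made for them only; others in the source may bear on it.

Measured so far in a functional assay on Huh-7 cells (Homo sapiens) for inhibition, read by sulforhodamine B assay, with a stated time of 72 h; a higher number here means a weaker inhibitor, a lower number a stronger inhibitor:
compound 1, `COc1ccc2cc(C(C)c3nnc4n3N=C(c3ccc(C(F)(F)F)cc3)CS4)ccc2c1`: 14800 nM
compound 2, `COc1ccc2cc(C(C)c3nnc4n3N=C(c3ccc(Cl)cc3Cl)CS4)ccc2c1`: 10700 nM
compound 3, `COc1ccc2cc(C(C)c3nnc4n3N=C(c3ccc([N+](=O)[O-])cc3)CS4)ccc2c1`: 14700 nM

Compound 3 stands second highest of the three numbers. Its nearest neighbour is compound 1, with a 1.0-fold lower number from compound 1 to compound 3 (0.00 log units; within the scatter); its furthest is compound 2, with a 1.4-fold higher number from compound 2 to compound 3 (0.14 log units; within the scatter). All three values thus lie within the scatter of one another, and no order among them can be read.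

Compound 4, `COc1ccc2cc(C(C)c3nnc4n3N=C(c3ccc(Br)cc3)CS4)ccc2c1`, is not yet measured. Relative to compound 3 the change is bromo in place of nitro on an aromatic carbon.

Among the compounds with values here, two measured steps bear on this. The exchange of a group on the same aromatic carbon, a 1.0-fold lower number from compound 1 to compound 3 (0.00 log units; within the scatter), and the exchange of the whole aryl group, a 1.4-fold higher number from compound 2 to compound 3 (0.14 log units; within the scatter), both stayed within the scatter. A further exchange at the same place is therefore expected to give no step beyond the scatter in this assay.

For compound 4 the expected step is a 1.1-fold lower number from compound 3 to compound 4 (0.05 log units; within the scatter). Compound 4 is estimated at 13000 nM, with a range from 6500 nM to 26000 nM.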

Compound 4, half-maximal inhibitory concentration: 9300 nM
The estimate for compound 4 lay 1.4-fold (0.15 log units) above the measured number, within the range that was stated.
By their numbers in this assay, from the lowest: compounds 4, 2, 3 and 1 (each within the scatter of the next).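

In this assay, bromo, with no hydrogen-bond acceptors, takes the place of nitro, with its two, on the aromatic carbon para to a large group, and the step stays within the scatter: a 1.6-fold lower number from compound 3 to compound 4 (0.20 log units; within the scatter). The comparisons with the other two aryl groups, a 1.6-fold lower number from compound 1 to compound 4 (0.20 log units; within the scatter) and a 1.2-fold lower number from compound 2 to compound 4 (0.06 log units; within the scatter), also stay within the scatter, so the four aryl groups on the shared core show no order among them. No supporting data on these groups accompany this result.

On these data alone, whether an amine, a carboxylic acid or a longer chain on this aromatic carbon would give a step beyond the scatter remains open. The compounds shown also hold the rest of the shared core constant, leaving the effect of any change there unknown.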